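The source may report more compounds than this note shows. Statements on the series, on what has been measured and on what is new or still open speak of the compounds shown alone.

Measured so far:
compound 1 `O=C1c2cc(COc3ccccc3)nn2CCN1c1ccc(F)cc1`: 79%
compound 2 `O=C1c2cc(COc3ccccc3)nn2CCN1c1ccncc1`: 72%

For the measured compounds named here, in a functional assay on HEK293 cells for positive allosteric modulation of metabotropic glutamate receptor 5 (Homo sapiens), read by calcium flux (on this read-out higher numbers stand for larger maximal responses and lower numbers for smaller maximal responses), compound 1 gives 79%, the higher of the two numbers known, while compound 2 gives 72%. Going by the values given here, the one measured step, a number 7 percentage points lower from compound 1 to compound 2 (within the scatter), is a change of pyridin-4-yl in place of 4-fluorophenyl on an amide-type nitrogen in a ring, and it stays within the scatter, so the two compounds cannot be told apart on this read-out.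

Compound 3 `O=C1c2cc(COc3cccnc3)nn2CCN1c1ccc(F)cc1` is the next compound. It differs from compound 1 by pyridin-3-yl in place of phenyl on an oxygen on a saturated carbon. Among the compounds with values here, no measured step touches this oxygen-linked ring; the only measured step, a number 7 percentage points lower from compound 1 to compound 2 (within the scatter), concerns a different position and an exchange of an all-carbon ring for a pyridine ring that made no difference beyond the scatter. On that slim basis, a change of similar kind elsewhere is expected to give a number 5 percentage points lower from compound 1 to compound 3 (within the scatter), nothing beyond the scatter. Compound 3 is therefore estimated at 74%, with a range from 58% to 90%.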

Compound 3, largest response reached (Emax), in percent of the reference or control that the assay uses: 69%
For compound 3 the middle estimate is 5 percentage points above the measured one; measured number inside the range.
By their numbers in this assay, from the lowest: compounds 3, 2 and 1 (each within the scatter of the next).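

The oxygen-linked ring now has a measured step of its own: in this assay, putting pyridin-3-yl in place of phenyl on an oxygen on a saturated carbon gives a number 10 percentage points lower from compound 1 to compound 3 (within the scatter). A ring nitrogen, which brings one hydrogen-bond acceptor, can therefore enter at this position with no change that stands out from the scatter, and the same holds at the amide-type nitrogen, where the earlier exchange gave a number 7 percentage points lower from compound 1 to compound 2 (within the scatter). No measurement at hand explains why the response stays in this range.

From the compounds shown here alone, it remains open how a pyridin-2-yl ring, a phenyl ring carrying a fluorine or a methoxy group, or a saturated ring such as piperidine would behave at this position. Also open, going by these compounds, is whether a compound with pyridine rings at both positions would still stay within the scatter of compound 1.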